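The source may hold more compounds than are shown below. What is called first, only, known or untested is meant among the compounds shown, and "the series" means these compounds.

Compound 1, with the structure `CNc1c(C#N)[n+]([O-])c2cc(Cl)ccc2[n+]1[O-]`, and compound 2, with the structure `Cc1c(C(=O)N=[N+]=[N-])[n+]([O-])c2cc(Cl)ccc2[n+]1[O-]`, share a common core and are both characterised in a functional assay on Ehrlich cells (Mus musculus) for cytotoxicity, read by trypan blue exclusion, with a stated time of 2 h, tested at 10 ug/mL; on this read-out lower numbers stand for a stronger effect and higher numbers for a weaker effect at the one concentration tested. In this assay compound 1 gives 92.7%. In this assay compound 2 gives 88.3%. The two numbers lie within the usual scatter of each other, so the data show no difference between compound 1 and compound 2 in this assay, and both stand near the weak end of the scale.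

Compound 3, with the structure `COc1ccc2c(c1)[n+]([O-])c(C(=O)N=[N+]=[N-])c(C)[n+]2[O-]`, has not yet been measured. It differs from compound 2 in one place: methoxy in place of chloro on an aromatic carbon. Within the data shown here, no pair of measured compounds shows a step of this kind, so nothing measured here tells how the exchange of chloro for methoxy on this aromatic carbon affects this assay.

Compound 3 is therefore expected to sit close to compound 2, with a step of a number 0.3 percentage points lower from compound 2 to compound 3 (within the scatter) that stays within the scatter. For compound 3 the estimated value in this assay is 88%, with a range from 74% to 98%.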

Compound 3, a percentage reported as activity, at one concentration (the size of the read-out at that concentration, not a potency): 58.3%
For compound 3 the middle estimate is 29.7 percentage points above the measured one, outside the stated range (below it).
By their numbers in this assay, from the lowest: compound 3; then compounds 2 and 1 (each within the scatter of the next).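

The aromatic carbon that is meta to a fused ring and para to a fused ring proves to matter in this assay: with the rest of the structure unchanged, methoxy in place of chloro gives a number 30 percentage points lower from compound 2 to compound 3 (beyond the scatter). Lower numbers stand for a stronger effect on this read-out. This is therefore the first sign among these compounds of a stronger effect at the one concentration tested, and it shows that the group on this carbon can alter the result by more than the usual scatter. The data offer no measurement that accounts for the step, so the reason for it remains unknown.

Going by these compounds, this single pair cannot show whether the effect belongs to methoxy itself or to the loss of chloro, and so it remains open whether a hydroxyl, an ethoxy group, a longer alkoxy chain or an amine on this carbon would shift the value further, less or the other way. It also leaves open whether the same exchange would have a comparable effect on the core of compound 1, which carries a nitrile and a methylamino group.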